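Swapping azido on the chain carbon for a larger group

This account rests on a few compounds, and the source may have more. Where it says the series, first, only, none or still open, it means among the compounds named here.

Compound 1 `COC/C1=C/C[C@](C)(CCC=C(C)C)/C=C/[C@@H](OC(=O)C=C(C)C)[C@](C)(O)/C=C/C1=O` gives 4130 nM
Compound 2 `CC(C)=CCC[C@]1(C)/C=C/[C@@H](OC(=O)C=C(C)C)[C@](C)(O)/C=C/C(=O)/C(CN(C(C)C)C(C)C)=C\C1` gives 780 nM
Compound 3 `CC(C)=CCC[C@]1(C)/C=C/[C@@H](OC(=O)C=C(C)C)[C@](C)(O)/C=C/C(=O)/C(CN=[N+]=[N-])=C\C1` gives 4890 nM

All three values come from a functional assay on MCF7 cells (Homo sapiens) for antiproliferative activity, read by MTT assay, with a stated time of 48 h (a higher number here means a weaker inhibitor, a lower number a stronger inhibitor), and no other read-out is available. Compound 3 at 4890 nM stands within the scatter of compound 1, and only compound 2 separates from the other two.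

The next analogue is compound 4 `CSC(=S)OC/C1=C/C[C@](C)(CCC=C(C)C)/C=C/[C@@H](OC(=O)C=C(C)C)[C@](C)(O)/C=C/C1=O` and its change from compound 3 reads a group of 5 heavy atoms (2 carbon, 1 oxygen, 2 sulfur; no ring) in place of a group of 3 heavy atoms (3 nitrogen; no ring), on a saturated chain carbon bound to a double-bonded ring carbon in full. Among the compounds with values here, the group that enters has no counterpart among the measured compounds, so the measured steps offer only indirect guidance. Methoxy and azido give a 1.2-fold higher number from compound 1 to compound 3 (0.07 log units; within the scatter) as their step. Both steps beyond the scatter involve diisopropylamino, namely a 5.3-fold lower number from compound 1 to compound 2 (0.72 log units; beyond the scatter) and a 6.3-fold higher number from compound 2 to compound 3 (0.80 log units; beyond the scatter) in turn. Compound 4 carries no diisopropylamino, so no step beyond the scatter is expected in this assay here. The estimated step is a 1.3-fold lower number from compound 3 to compound 4 (0.11 log units; within the scatter) and its direction is uncertain. The estimate for compound 4 is 3800 nM with an expected range from 1400 nM to 10000 nM on this evidence.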

Compound 4, half-maximal inhibitory concentration: 900 nM
Compound 4: the middle estimate sits 4.2-fold (0.63 log units) above what was measured, outside the stated range (below it).
By their numbers in this assay, from the lowest: compounds 2 and 4 (each within the scatter of the next); then compounds 1 and 3 (each within the scatter of the next).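

In this assay, a step beyond the scatter at this saturated chain carbon no longer belongs to diisopropylamino alone: the group of 5 heavy atoms (2 carbon, 1 oxygen, 2 sulfur; no ring) gives a 5.4-fold lower number from compound 3 to compound 4 (0.74 log units; beyond the scatter), and the change on the oxygen gives a 4.6-fold lower number from compound 1 to compound 4 (0.66 log units; beyond the scatter). Two groups of different atom content also fall together, with a 1.2-fold higher number from compound 2 to compound 4 (0.06 log units; within the scatter), so compound 2 and compound 4 form one level and compound 1 and compound 3 another. No measurement on hand bears on why the groups divide in this way.

Four compounds cannot separate a contribution from the sulfur atoms from one tied to the heavy-atom count of the entering group. Dimethylamino, a longer alkoxy chain or a simple thioether on the same carbon would bear on that question.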